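This account rests on a few compounds, and the source may have more. Where it says the series, first, only, none or still open, it means among the compounds named here.

The three compounds measured in an assay on isolated protein for inhibition of Gonadotropin-releasing hormone receptor (Homo sapiens) (on this read-out lower numbers stand for stronger inhibition and higher numbers for weaker inhibition), are compound 1 `COc1ccc(C(C)=O)cc1CSc1nc2cc(NC(=O)C3CC3)ccc2n1C(C)C` with 260 nM, compound 2 `COc1ccc([N+](=O)[O-])cc1CSc1nc2cc(NC(=O)NC(C)(C)C)ccc2n1C1CC1` with 79 nM, and compound 3 `COc1ccc([N+](=O)[O-])cc1CSc1nc2cc(NC(=O)NC(C)(C)C)ccc2n1Cc1ccccc1` with 28 nM.

Compound 2 therefore stands second highest of the three numbers. Its nearest neighbour is reached by the step of a 2.8-fold lower number from compound 2 to compound 3 (0.45 log units; beyond the scatter); compound 1, the furthest, shows a higher number than compound 2.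

Compound 4 `COc1ccc([N+](=O)[O-])cc1CSc1nc2cc(NC(=O)NC(C)(C)C)ccc2n1Cc1ccccn1` differs from compound 2 by one change: (pyridin-2-yl)methyl in place of cyclopropyl on an aromatic nitrogen. For the measured compounds named here, the only measured step that bears on it is a 2.8-fold lower number from compound 2 to compound 3 (0.45 log units; beyond the scatter), where another group on that aromatic nitrogen took the place of cyclopropyl. A step of similar size and direction is expected here, a 2.6-fold lower number from compound 2 to compound 4 (0.42 log units; beyond the scatter). Compound 4 is thus estimated at 30 nM, within a range from 10 nM to 90 nM.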

Compound 4, half-maximal inhibitory concentration: 43 nM
The estimate for compound 4 lay 1.4-fold (0.16 log units) below the measured number; the range from low to high includes it.
By their numbers in this assay, from the lowest: compounds 3, 4 and 2 (each within the scatter of the next, the first and the last beyond it); then compound 1.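

In this assay, (pyridin-2-yl)methyl in place of cyclopropyl gives a 1.8-fold lower number from compound 2 to compound 4 (0.26 log units; within the scatter), so unlike the benzyl group of compound 3, this group cannot be told apart from cyclopropyl on the aromatic nitrogen. Pyridin-2-yl in place of phenyl gives a 1.5-fold higher number from compound 3 to compound 4 (0.19 log units; within the scatter), so the ring nitrogen, with its hydrogen-bond acceptor, brings no clear difference from phenyl at this position. Nothing at hand explains either step.

The compounds shown leave open how (pyridin-4-yl)methyl, or an aminoethyl chain, would read on this nitrogen. They also leave open whether a carboxylic acid on the benzyl ring would separate from compound 3.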